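The source may report more compounds than this note shows. Statements on the series, on what has been measured and on what is new or still open speak of the compounds shown alone.

Working notes on the series, step from compound 3 to compound 4.

Of the compounds shown here, three sharing one core have been measured in a functional assay on LOX IMVI cells (Homo sapiens) for inhibition, read by sulforhodamine B assay, with a stated time of 48 h, tested at 10 uM; a lower number here means less inhibition, a higher number more inhibition at the concentration tested (going by the name of the read-out). Compound 1, `Brc1cn2ccnc2c(-c2ccc3ncn(C4CCCCC4)c3c2)n1`, gives 15.2%. Compound 2, `COc1ccc(-c2cn3ccnc3c(-c3ccc4ncn(C5CCCCC5)c4c3)n2)cc1`, gives 69.6%. Compound 3, `CC(=O)c1ccc(-c2cn3ccnc3c(-c3ccc4ncn(C5CCCCC5)c4c3)n2)cc1`, gives 14.5%. On these numbers compound 3 stands lowest of the three; its nearest neighbour is compound 1, and that gap is within the scatter, while compound 2 lies far above it, beyond the scatter.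

Compound 4 is `FC(F)(F)c1cccc(-c2cn3ccnc3c(-c3ccc4ncn(C5CCCCC5)c4c3)n2)c1`. Its difference from compound 3 is 3-(trifluoromethyl)phenyl in place of 4-acetylphenyl on an aromatic carbon.

Going by the values given here, two measured steps touch the same position. The step of a number 55.1 percentage points lower from compound 2 to compound 3 (beyond the scatter) shows that exchanging the group on this phenyl can move the read-out a great deal. The step of a number 0.7 percentage points lower from compound 1 to compound 3 (within the scatter) shows that a bromo and a 4-acetylphenyl at this carbon give the same outcome within the scatter. Among the compounds with values here, the step of a number 54.4 percentage points higher from compound 1 to compound 2 (beyond the scatter) is the only one that raises the number. Within the data shown here, no measured compound carries a 3-(trifluoromethyl)phenyl, so the direction for compound 4 rests on little.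

For compound 4 a step of a number 11.5 percentage points higher from compound 3 to compound 4 (beyond the scatter) is expected, small and likely within the scatter, because only compound 2 with 69.6% departs from the low level. Compound 4 is estimated at 26%, within 5% to 60%.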

Compound 4, a percentage reported as inhibition, at one concentration (the size of the read-out at that concentration, not a potency): 3.45%
Estimate against measurement, compound 4: 22.6 percentage points above, outside the stated range (below it).
By their numbers in this assay, from the lowest: compound 4; then compounds 3 and 1 (each within the scatter of the next); then compound 2.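

In this assay, the step of a number 11.1 percentage points lower from compound 3 to compound 4 (beyond the scatter) and the step of a number 11.8 percentage points lower from compound 1 to compound 4 (beyond the scatter) show that the low level shared by the bromo and 4-acetylphenyl compounds is not the bottom of the range at this carbon, since 3-(trifluoromethyl)phenyl gives a still lower number. The step of a number 66.2 percentage points lower from compound 2 to compound 4 (beyond the scatter) adds a second substituted phenyl that falls far short of 4-methoxyphenyl, so a phenyl at this carbon does not by itself bring a high number, and among the compounds shown only compound 2 departs upward. Nothing measured on these compounds accounts for these steps.

The exchange of 4-acetylphenyl for 3-(trifluoromethyl)phenyl alters both the group on the phenyl and its place on that ring, and the compounds shown do not separate the two. Going by these compounds, it also stays open whether the high number of compound 2 depends on methoxy specifically, and what an amine or a carboxylic acid on this phenyl would give.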